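The compounds below may be only part of what the source reports. "The series", "measured", "known", "first", "only" and "open" are said of these compounds alone.

Compound 2 `COc1ccc(C(=O)/C=C/c2cc(-c3cc(OC)c(OC)c(OC)c3)n[nH]2)cc1` gives 1920 nM in a functional assay on NCI-H322M cells (Homo sapiens) for inhibition, read by sulforhodamine B assay, with a stated time of 48 h; a lower number here means a stronger inhibitor of growth, a higher number a weaker inhibitor of growth. Of the two numbers recorded, compound 2 holds the lowest, yet compound 1 `COc1ccc(-c2cc(/C=C/C(=O)c3cc(OC)c(OC)c(OC)c3)[nH]n2)cc1OC` lies within the scatter of it, since compound 1 gives 2020 nM. Compound 3 `COc1cc(-c2cc(/C=C/C(=O)c3ccc(F)c(F)c3)[nH]n2)cc(OC)c1OC` differs from compound 2 only as 3,4-difluorophenyl in place of 4-methoxyphenyl on a carbonyl carbon. For the measured compounds named here, no step of this kind has been measured in the set, so the change is expected to move compound 3 little, perhaps towards a slightly weaker growth inhibitor but not clearly beyond the scatter, with an estimated step of a 1.6-fold higher number from compound 2 to compound 3 (0.19 log units; within the scatter). Compound 3 is therefore estimated at 3000 nM, between 1000 nM and 9000 nM.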

Compound 3, concentration for 50% growth inhibition: 3370 nM
Beside the measured number, compound 3's estimate is 1.1-fold (0.05 log units) below it; the range from low to high includes it.
By their numbers in this assay, from the lowest: compounds 2, 1 and 3 (each within the scatter of the next).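

In this assay, 3,4-difluorophenyl in place of 4-methoxyphenyl on a carbonyl carbon gives a 1.8-fold higher number from compound 2 to compound 3 (0.24 log units; within the scatter), so this place accepts the loss of the methoxy oxygen, the one hydrogen-bond acceptor counted in the leaving group, without a change that stands clear of the scatter. No available evidence bears on this result. As far as these compounds go, whether an amine or a carboxylic acid on this phenyl ring, or a longer chain in place of the ring, would move the number beyond the scatter stays open.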